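Aminotriazine piperazines: sulfur for oxygen at the benzylic link

The source may hold more compounds than are shown below. What is called first, only, known or untested is meant among the compounds shown, and "the series" means these compounds.

Measured in an assay on HEK293 cells for displacement of a labelled ligand from 5-hydroxytryptamine receptor 7 (Homo sapiens), read by radioligand binding, with a stated time of 1 h; on this read-out higher numbers stand for weaker inhibition and lower numbers for stronger inhibition:
- compound 1 `CN1CCN(c2nc(N)nc(COc3ccccc3Cl)n2)CC1` gives 9250 nM
- compound 2 `Cc1cc(Cl)ccc1OCc1nc(N)nc(N2CCN(C)CC2)n1` gives 15200 nM
- compound 3 `CC(Oc1ccccc1Cl)c1nc(N)nc(N2CCN(C)CC2)n1` gives 38700 nM

Compound 3 holds the highest number of the three; the shift a 4.2-fold higher number from compound 1 to compound 3 (0.62 log units; beyond the scatter) is the larger of the two recorded steps, while a 1.6-fold higher number from compound 1 to compound 2 (0.22 log units; within the scatter) stays within the scatter. Compound 4 `CC(Sc1ccccc1Cl)c1nc(N)nc(N2CCN(C)CC2)n1` differs from compound 3 only in the linking atom: (2-chlorophenyl)sulfanyl in place of 2-chlorophenoxy on a saturated chain carbon bound to an aromatic carbon and a saturated chain carbon. Going by the values given here, no measured pair exchanges oxygen for sulfur, so neither recorded step bears on this change; the series gives no basis for a direction, and a step of no more than the scatter is expected in this assay. Compound 4 is therefore estimated at 35000 nM (range 10000 nM to 120000 nM), a step of a 1.1-fold lower number from compound 3 to compound 4 (0.04 log units; within the scatter) that is expected to be modest at most.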

Compound 4, inhibition constant: 4570 nM
For compound 4 the middle estimate is 7.7-fold (0.88 log units) above the measured one, and the stated range ends above it.
By their numbers in this assay, from the lowest: compound 4; then compounds 1 and 2 (each within the scatter of the next); then compound 3.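

Exchanging the linking atom alone moves the number in this assay: (2-chlorophenyl)sulfanyl in place of 2-chlorophenoxy gives an 8.5-fold lower number from compound 3 to compound 4 (0.93 log units; beyond the scatter). Going by these compounds alone, the earlier steps changed the aryl group or added the chain methyl, so this is the first sign that the link itself matters at this position, even though the counts of heavy atoms, donors and acceptors stay the same. No supporting data on hand bear on why the number moves.

From the compounds shown here alone, whether the gain carries over to the unbranched link of compound 1 remains open. So does the outcome with a sulfonyl or an amine nitrogen as the link.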